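Back From the Sulfamoylphenyl Limit Toward a Pyridyl Ring

The compounds below may be only part of what the source reports. "The series", "measured", "known", "first", "only" and "open" are said of these compounds alone.

Compound 1 `O=C(O)Cc1sc(C(c2ccc(F)cc2)c2ccc(F)cc2)nc1-c1ccco1` carries a furan-2-yl group on an aromatic carbon of the shared core, and in an in vitro functional assay on HEK285-7 cells for antagonist activity at prostaglandin D2 receptor 2 (Homo sapiens), read by BRET and beta-arrestin recruitment (a higher number here means a weaker inhibitor, a lower number a stronger inhibitor), compound 1 gives 140 nM. Compound 2 `COc1cc(-c2nc(C(c3ccc(F)cc3)c3ccc(F)cc3)sc2CC(=O)O)ccn1` bears a 2-methoxypyridin-4-yl group in its place; in this assay compound 2 gives 380 nM, which is a 2.7-fold higher number from compound 1 to compound 2 (0.43 log units; beyond the scatter). Compound 3 `NS(=O)(=O)c1ccc(-c2nc(C(c3ccc(F)cc3)c3ccc(F)cc3)sc2CC(=O)O)cc1` carries a 4-sulfamoylphenyl group on the same aromatic carbon. For compound 3 this assay returns only a limit, > 100000 nM, and not a number. Compound 3 thus stands at the weak end of the three, sitting at the limit of > 100000 nM in this assay, at which 1 of the 3 values shown sits, reached by an at least 710-fold higher number from compound 1 to compound 3 (2.85 log units; beyond the scatter) and by an at least 260-fold higher number from compound 2 to compound 3 (2.42 log units; beyond the scatter).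

Compound 4 `O=C(O)Cc1sc(C(c2ccc(F)cc2)c2ccc(F)cc2)nc1-c1cc(F)nc(F)c1` is the next step: 2,6-difluoropyridin-4-yl in place of 4-sulfamoylphenyl on an aromatic carbon. Both measured steps that bear on this change are the two in which 4-sulfamoylphenyl entered and the number rose by a large amount; compound 4 removes that group again and returns to a six-membered aromatic ring with one hetero atom, closer in kind to compound 2 than to compound 3. Compound 4 is therefore expected to give a much lower number, a step estimated at an at least 200-fold lower number from compound 3 to compound 4 (2.30 log units; beyond the scatter). The estimate for compound 4 in this assay is 500 nM, with a range from 100 nM to 5000 nM.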

Compound 4, half-maximal inhibitory concentration: 110 nM
The estimate for compound 4 lay 4.5-fold (0.66 log units) above the measured number; low and high end bracket the measured number.
By their numbers in this assay, from the lowest: compounds 4 and 1 (each within the scatter of the next); then compound 2. At a limit, above all of these: compound 3.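

In this assay compound 3 remains a limit and not a number: the limit of > 100000 nM in this assay, at which 1 of the 4 values shown sits. Replacing 4-sulfamoylphenyl with 2,6-difluoropyridin-4-yl on the aromatic carbon next to the ring nitrogen gives an at least 900-fold lower number from compound 3 to compound 4 (2.95 log units; beyond the scatter) and so shows that this position, where the earlier compounds had shown a large rise with a six-membered aromatic ring of carbon only, can carry a six-membered aromatic ring with 1 hetero atom and still give a low number. Compound 2 alone had left that kind of ring with a modestly higher number than furan-2-yl, but a 3.5-fold lower number from compound 2 to compound 4 (0.54 log units; beyond the scatter) shows that the groups on the pyridyl ring matter, and a 1.3-fold lower number from compound 1 to compound 4 (0.10 log units; within the scatter) places the new ring within the scatter of furan-2-yl, so a six-membered ring here need not cost anything against the five-membered one.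

The compounds shown leave open how much of this comes from the two fluorines, since an unsubstituted pyridin-4-yl would separate them from the ring nitrogen. They also leave open whether the large rise with compound 3 belongs to the sulfamoyl group or to its carbon-only ring, which a plain phenyl group would begin to separate.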